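Series notes: acetyl for hydrogen on a ring oxygen

A few compounds are considered here, and "the series" means these few. Any claim that something is new, unique, unknown or untested is made for them only; others in the source may bear on it.

Measured so far:
Compound 1 `O=C(O)c1cc(F)c(F)c(F)c1O`: 66%
Compound 2 `O=C(O)c1cc(F)c(F)cc1O`: 66%
Compound 3 `O=C(O)c1c(O)c(F)cc(F)c1F`: 66%

In a toxicity assay on the whole organism (strain CD-1) for cytotoxicity, with Mus musculus as the target, with a stated time of 14 days, at a dose of 150 mg/kg by the intraperitoneal route (on this read-out lower numbers stand for a stronger effect and higher numbers for a weaker effect at the one dose given), compound 1 gives 66%, compound 2 gives 66% and compound 3 gives 66%. Compound 2 thus stands level with compounds 1 and 3 at the digits recorded; nothing separates the three beyond the scatter. For the measured compounds named here, the only step between two measured compounds that differ in one place is no change at the digits printed from compound 1 to compound 2 (within the scatter), hydrogen in place of fluoro on an aromatic carbon, and it lies within the scatter.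

Compound 4 `CC(=O)Oc1cc(F)c(F)cc1C(=O)O` differs from compound 2 by acetyl in place of hydrogen on an oxygen on an aromatic ring. Going by the values given here, no measured step touches the oxygen on the aromatic ring; the single step available concerns an aromatic carbon and bears on this change only loosely. With all three values at one level and that step flat, nothing in the data points to a direction for the new change in this assay. The step is therefore expected to be no change at the digits printed from compound 2 to compound 4 (within the scatter), no change beyond the scatter. Compound 4 is estimated at 66%, with a range from 50% to 82%.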

Compound 4, a percentage reported as activity, at one dose (the size of the read-out at that dose, not a potency): 100%
Compound 4: the middle estimate sits 34 percentage points below what was measured; the whole stated range lies below it.
By their numbers in this assay, from the lowest: compounds 1, 2 and 3 (each within the scatter of the next); then compound 4.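

In this assay the oxygen on the aromatic ring responds where the aromatic carbon did not: a number 34 percentage points higher from compound 2 to compound 4 (beyond the scatter) with acetyl in place of hydrogen, whereas no change at the digits printed from compound 1 to compound 2 (within the scatter) with hydrogen in place of fluoro. The direction of this step is towards the weaker effect at the one dose given, so hydroxy to acetoxy is the only change shown that separates two compounds beyond the scatter. No measurement shown bears on what lies behind this step.

A methyl or a propionyl on the same oxygen would show whether the shift belongs to acetyl itself or extends to other replacements of that hydrogen. Going by these compounds, whether hydroxy to acetoxy gives a similar step on the cores of compound 1 and compound 3 also remains open.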